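This account rests on a few compounds, and the source may have more. Where it says the series, first, only, none or still open, it means among the compounds named here.

Measured so far in an assay on isolated protein for inhibition of vitamin D3 receptor (Homo sapiens), read by fluorescence polarization; a higher number here means a weaker inhibitor, a lower number a stronger inhibitor:
compound 1 `CC1CCN(C(=O)CCCNC(=O)c2ccc(S(C)(=O)=O)c([N+](=O)[O-])c2)CC1` — > 60000 nM, a limit of the assay, not a number.
compound 2 `CS(=O)(=O)c1ccc(C(=O)NCCCC(=O)N2Cc3ccccc3C2)cc1[N+](=O)[O-]` — > 60000 nM, likewise only a limit.
compound 3 `CN(Cc1cccc(F)c1)C(=O)CNC(=O)c1ccc(S(C)(=O)=O)c([N+](=O)[O-])c1` — > 60000 nM, again a limit.

Compound 2 thus stands only as a limit in this assay, and the two other values shown are limits too (the limit of > 60000 nM in this assay, at which 3 of the 3 values shown sit). For the measured compounds named here, the one step between measured compounds, a step that the two limits leave unreadable from compound 1 to compound 2, is unreadable for the same reason.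

Compound 4 `CN(Cc1ccccc1F)C(=O)CCCNC(=O)c1ccc(S(C)(=O)=O)c([N+](=O)[O-])c1` differs from compound 2 by a group of 10 heavy atoms (8 carbon, 1 nitrogen, 1 fluorine; one six-membered aromatic ring of carbon only) in place of a group of 9 heavy atoms (8 carbon, 1 nitrogen; one five-membered non-aromatic ring with 1 hetero atom, one six-membered aromatic ring of carbon only), on a carbonyl carbon. Going by the values given here, no measured step bears readably on this change, so no direction can be taken from the series. The expected step that the limit leaves unreadable from compound 2 to compound 4 is therefore most likely again hidden behind the limit. Compound 4 is estimated at 100000 nM, within 20000 nM to 500000 nM, and expected to be reported as a limit.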

Compound 4, half-maximal inhibitory concentration: > 60000 nM
Compound 4 gave a limit, no number; the forecaster's own chance of this, stated with the estimate: 85%; the middle value lies beyond the limit too.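

In this assay compound 4 gives > 60000 nM as a limit and not a number, so the steps from compound 1 and from compound 2 to compound 4 cannot be read: the limit of > 60000 nM in this assay, at which 4 of the 4 values shown sit. The compounds shown leave open which change, if any, would give a measurable value.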